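The source may hold more compounds than are shown below. What is called first, only, known or untested is meant among the compounds shown, and "the series" means these compounds.

Within the data shown here, compound 1 `COc1cc(/C=C/C(=O)c2ccccc2OCC(=O)NCCNc2ccnc3cc(Cl)ccc23)cc(OC)c1OC` is one of two compounds so far measured in an ADME assay on Vero cells (Chlorocebus sabaeus) for cytotoxicity, read by MTT assay, with a stated time of 72 h (on this read-out lower numbers stand for higher toxicity in this test and higher numbers for lower toxicity in this test), where compound 1 gives 3920 nM. Compound 2 `Cc1ccc(/C=C/C(=O)NCCNc2ccnc3cc(Cl)ccc23)cc1` gives 4000 nM in this assay, and the two numbers lie within the scatter of each other, so compound 1 stands level with compound 2. Compound 3 `COc1ccc(/C=C/C(=O)c2ccccc2OCC(=O)NCCNc2ccnc3cc(Cl)ccc23)cc1` is not yet measured; it differs from compound 1 by 4-methoxyphenyl in place of 3,4,5-trimethoxyphenyl on a double-bonded chain carbon bound to a double-bonded chain carbon. Among the measured compounds shown here, no step between measured compounds bears on this change, so no shift beyond the scatter is expected in this assay. For compound 3 the estimate is 4000 nM, with a range from 1800 nM to 9000 nM. The expected step is a 1.0-fold higher number from compound 1 to compound 3 (0.01 log units; within the scatter).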

Compound 3, half-maximal cytotoxic concentration: 25000 nM
Estimate against measurement, compound 3: 6.3-fold (0.80 log units) below; measured number outside the range, above it.
By their numbers in this assay, from the lowest: compounds 1 and 2 (each within the scatter of the next); then compound 3.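

In the series, the group on a double-bonded chain carbon bound to a double-bonded chain carbon is now shown to affect the number in this assay: 4-methoxyphenyl in place of 3,4,5-trimethoxyphenyl gives a step beyond the scatter (a 6.4-fold higher number from compound 1 to compound 3 (0.80 log units; beyond the scatter)). Compounds 1 and 2 differ in more than one place, so their pair could not isolate this change. No measurement on hand accounts for the step.

Still open, from the compounds shown here alone, is whether unsubstituted phenyl or 3,4-dimethoxyphenyl at this place would give a number nearer compound 1 or compound 3. Going by these compounds, it is also open whether the step carries over to other parts of the series.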